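This account rests on a few compounds, and the source may have more. Where it says the series, first, only, none or still open, it means among the compounds named here.

Measured compounds:
Compound 1, `Cc1nnc(SCc2cc(=O)c3ccccc3o2)s1`: in a functional assay on MDA-MB-435S cells (Homo sapiens) for cytotoxicity, read by MTT assay, with a stated time of 72 h (a lower number here means a stronger inhibitor, a higher number a weaker inhibitor), compound 1 gives > 25000 nM, which is a limit of the assay and not a number.
Compound 2, `Nc1nnc(SCc2cc(=O)c3cc(Cl)ccc3o2)s1`: in this assay compound 2 gives > 25000 nM, again a limit of the assay.
Compound 3, `Cc1ccc2oc(CSc3nnc(C)s3)cc(=O)c2c1`: in this assay compound 3 gives > 25000 nM, also a limit of the assay.

Compound 3 therefore stands nowhere on a scale of numbers: every value shown sits at the same limit, as the limit of > 25000 nM in this assay, at which 3 of the 3 values shown sit, records. The only measured step between two of these compounds, a step that the two limits leave unreadable from compound 1 to compound 3, is unreadable for the same reason, since both of its ends are limits.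

Compound 4, `Cc1nnc(SCc2cc(=O)c3cc(Cl)ccc3o2)s1`, differs from compound 3 by chloro in place of methyl on an aromatic carbon. For the measured compounds named here, no measured step bears on this change. Compound 2 also carries a chloro on that ring, and in this assay it too reaches only a limit. Nothing measured points to a change beyond the scatter, so the step from compound 3 to compound 4 is expected to be a step that the limit leaves unreadable from compound 3 to compound 4. Compound 4 is estimated at 35000 nM, within 15000 nM to 90000 nM, most likely again reported only as a limit.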

Compound 4, half-maximal inhibitory concentration: > 25000 nM
Compound 4: a limit, no number (the forecaster's own chance of this, stated with the estimate: 85%); the middle value is on the limit's open side.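

No step can be read between compound 4 and compound 1, compound 2 or compound 3, since each of them gives only a limit of the assay and not a number: the limit of > 25000 nM in this assay, at which 4 of the 4 values shown sit.

The compounds shown leave open how strongly any of them acts in this assay, and whether swapping methyl, chloro or amino changes that at all.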